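A few compounds are considered here, and "the series" means these few. Any claim that something is new, unique, unknown or untested is made for them only; others in the source may bear on it.

The three measured compounds share one core and differ only in the aryl group carried on the urea. Growth inhibition is followed in a functional assay on RT-112 cells (Homo sapiens) for antiproliferative activity, read by MTT assay, with a stated time of 72 h; a lower number here means a stronger inhibitor of growth, a higher number a weaker inhibitor of growth. Compound 1 `COc1cc(Nc2ncnc3c(NC(=O)Nc4cccc(Oc5ccccc5)c4)cccc23)cc(OC)c1`, with a 3-phenoxyphenyl urea, gives 14000 nM in this assay. Compound 2 `COc1cc(Nc2ncnc3c(NC(=O)Nc4cc(F)cc(F)c4)cccc23)cc(OC)c1`, with a 3,5-difluorophenyl urea, gives 2630 nM, the lowest of the two numbers shown; compound 1 sits higher by a margin beyond the usual scatter. For compound 3 `COc1cc(Nc2ncnc3c(NC(=O)Nc4ccc(C(F)(F)F)cc4[N+](=O)[O-])cccc23)cc(OC)c1` the assay reports only a limit, > 20000 nM, so no number is available for it. the limit of > 20000 nM in this assay, at which 1 of the 3 values shown sits, marks that one of the three values shown is such a limit.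

Compound 4 `COc1cc(Nc2ncnc3c(NC(=O)Nc4ccc(Cl)c(Cl)c4)cccc23)cc(OC)c1` is not yet measured. It differs from compound 2 in one place: 3,4-dichlorophenyl in place of 3,5-difluorophenyl on an amide-type nitrogen, the new group sitting on the same amide-type nitrogen whose other neighbour is the carbonyl carbon. Within the data shown here, no step between two measured compounds is available, so the expectation rests on compound 2 alone, whose 2630 nM is the lower of the two numbers. Both groups are halogenated phenyl rings of the same size, so the exchange is expected to move the value little, within or near the scatter, in either direction. The step from compound 2 to compound 4 is estimated as a 1.3-fold lower number from compound 2 to compound 4 (0.12 log units; within the scatter). For compound 4 the expected value is 2000 nM, with a range from 600 nM to 7000 nM.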

Compound 4, concentration for 50% growth inhibition: 6230 nM
Estimate against measurement, compound 4: 3.1-fold (0.49 log units) below, within the range that was stated.
By their numbers in this assay, from the lowest: compound 2; then compound 4; then compound 1. At a limit, above all of these: compound 3.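

In this assay the aryl group on the urea proves sensitive to a change within the halogenated phenyl rings: 3,4-dichlorophenyl in place of 3,5-difluorophenyl on the amide-type nitrogen gives a 2.4-fold higher number from compound 2 to compound 4 (0.37 log units; beyond the scatter) and so separates two groups that have the same heavy-atom count and the same hydrogen-bond donor and acceptor counts. Among these compounds, this is the first single exchange between two numerical values where both groups are halogenated phenyl rings, and it shows that halogen substitution alone does not fix the value at this place, although it rests on one pair only. Nothing available explains the size or direction of this step.

The exchange alters the halogen and its placement on the ring together, so the compounds shown cannot assign the step to either change; 3,5-dichlorophenyl and 3,4-difluorophenyl would separate the two. Also open, as far as these compounds go, is how this position responds to a ring carrying a non-halogen group such as a dimethylamino group or a carboxylic acid, and whether any such group gives a lower number than the 3,5-difluorophenyl urea.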